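The source may hold more compounds than are shown below. What is called first, only, known or untested is meant among the compounds shown, and "the series" means these compounds.

Measured in a functional assay on brain (Rattus norvegicus, strain Wistar) for inhibition; a lower number here means a stronger inhibitor, a higher number a weaker inhibitor:
- compound 1 `CCCCOc1ccc(-c2c(C)[nH]c(=O)n2C2CCCCC2)cc1`: 13900 nM
- compound 2 `CCCCCCc1ccc(-c2c(C)[nH]c(=O)n2C)cc1`: 9000 nM
- compound 3 `Cc1[nH]c(=O)n(C2CCCCC2)c1-c1ccc(OCCC(C)C)cc1`: 7200 nM

Compound 3, at 7200 nM, holds the lowest number of the three, but it lies within the scatter of both compound 1 and compound 2.

The next structure is compound 4 `CCCCCCc1ccc(-c2c(C)[nH]c(=O)n2C2CCCCC2)cc1`, with hexyl in place of isopentyloxy on an aromatic carbon, para to a large group (hexyl in place of isopentyloxy on an aromatic carbon).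

Within the data shown here, only one measured step bears on this directly. That step, a 1.9-fold lower number from compound 1 to compound 3 (0.29 log units; within the scatter), is methyl in place of hydrogen on a saturated chain carbon and stays within the scatter. Among the measured compounds shown here, it does not replace the isopentyloxy group, so no measured step matches this change exactly. Compound 2 also carries hexyl, with methyl where compound 4 has cyclohexyl, and compound 2 gives 9000 nM. This value lies close to the others, so no shift beyond the scatter is expected in this assay, in either direction.

The expected change is a 1.0-fold lower number from compound 3 to compound 4 (0.01 log units; within the scatter).

For compound 4 the estimate is 7000 nM, with an expected range from 2500 nM to 20000 nM.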

Compound 4, half-maximal inhibitory concentration: 13700 nM
Compound 4: middle estimate off by 2.0-fold (0.29 log units), on the low side; the measured number falls inside the stated range.
By their numbers in this assay, from the lowest: compounds 3, 2, 4 and 1 (each within the scatter of the next).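

In this assay, hexyl in place of isopentyloxy on an aromatic carbon, para to a large group, stays within the scatter (a 1.9-fold higher number from compound 3 to compound 4 (0.28 log units; within the scatter)), and hexyl in place of butoxy does the same (a 1.0-fold lower number from compound 1 to compound 4 (0.01 log units; within the scatter)), so at this place an all-carbon chain and both ether-linked chains cannot be told apart. The other place shows no readable shift either: cyclohexyl in place of methyl on an aromatic nitrogen also stays within the scatter (a 1.5-fold higher number from compound 2 to compound 4 (0.18 log units; within the scatter)). Nothing at hand accounts for how closely these values sit.

All the steps shown lie within the scatter, so no change at either place has yet been seen to move the number beyond it. Open, on these data alone, is whether a longer chain, or an amine or carboxylic acid at the end of the chain, would do so.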